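Prenyl Ether Chalcones Against 5-Lipoxygenase: A Methoxy Question

The source may report more compounds than this note shows. Statements on the series, on what has been measured and on what is new or still open speak of the compounds shown alone.

Measured so far:
compound 1 `COc1ccc(/C=C/C(=O)c2ccc(OCC=C(C)C)cc2O)c(OC)c1OC` — > 100000 nM
compound 2 `COc1ccc(/C=C/C(=O)c2ccc(OCC=C(C)C)cc2O)cc1OC` — > 100000 nM
compound 3 `COc1ccc(/C=C/C(=O)c2ccc(OCC=C(C)C)cc2OCC=C(C)C)cc1OC` — 9000 nM

In an assay on isolated protein for inhibition of Polyunsaturated fatty acid 5-lipoxygenase (Homo sapiens) (a lower number here means a stronger inhibitor, a higher number a weaker inhibitor), compound 1 gives only a limit of the assay, > 100000 nM. Compound 2 likewise gives only a limit, > 100000 nM. For the measured compounds named here, compound 3 gives the one real number, 9000 nM in this assay.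

Compound 2 and compound 3 share a core that differs in this way: 3-methylbut-2-en-1-yl in place of hydrogen on an oxygen on an aromatic ring. That change gives an at least 11-fold lower number from compound 2 to compound 3 (1.04 log units; beyond the scatter).

Compound 2 and compound 1 differ by methoxy in place of hydrogen on an aromatic carbon. Its step is a step that the two limits leave unreadable from compound 2 to compound 1, since both values sit at the limit of > 100000 nM in this assay, at which 2 of the 3 values shown sit.

Compound 4 `COc1cc(/C=C/C(=O)c2ccc(OCC=C(C)C)cc2OCC=C(C)C)cc(OC)c1OC` is not yet measured in this assay. It differs from compound 3 by methoxy in place of hydrogen on an aromatic carbon. This is the same kind of change as that from compound 2 to compound 1, but around the place the surroundings differ: in compound 1 the entering methoxy sits ortho to a large group, whereas in compound 4 it sits meta to a large group. Going by the values given here, because the earlier step that the two limits leave unreadable from compound 2 to compound 1 cannot be read, the only anchor is compound 3 with 9000 nM, and compound 4 is expected to stay close to it, with an estimated step of no change at the digits printed from compound 3 to compound 4 (within the scatter). Compound 4 is therefore estimated at 9000 nM, between 3500 nM and 25000 nM.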

Compound 4, half-maximal inhibitory concentration: 4000 nM
Compound 4: middle estimate off by 2.3-fold (0.35 log units), on the high side; the range from low to high includes it.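

In this assay, methoxy in place of hydrogen on an aromatic carbon gives a 2.3-fold lower number from compound 3 to compound 4 (0.35 log units; beyond the scatter), a modest gain on the core of compound 3, where the entering methoxy sits meta to a large group. For the compounds shown here, the same kind of change on the core of compound 2, which leads to compound 1, cannot be read, and its place on the ring also differs, so the two cores offer no pair of sizes to set side by side: the limit of > 100000 nM in this assay, at which 2 of the 4 values shown sit. The result therefore shows what this change does on one core only, and it does not show that the gain carries over to another core in this series.

As far as these compounds go, it remains open whether an ethoxy group or a longer chain at the same aromatic carbon would lower the number further than methoxy does, and whether an amine or a carboxylic acid there would be tolerated. Also open, from the compounds shown here alone, is how a longer chain in place of 3-methylbut-2-en-1-yl on the oxygens would change the picture.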